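Swapping the Amine on Two Fused-Ring Positions

The source may report more compounds than this note shows. Statements on the series, on what has been measured and on what is new or still open speak of the compounds shown alone.

Measured so far:
compound 1 `CC(=O)N1CCN(c2cccc3c2ccn3S(=O)(=O)c2ccccc2)CC1` — 714 nM
compound 2 `O=S(=O)(c1ccccc1)n1ccc2c(N3CCCCC3)cccc21` — 128 nM
compound 3 `CC(=O)N1CCN(c2ccc3c(ccn3S(=O)(=O)c3ccccc3)c2)CC1` — 4850 nM

Three compounds have been examined in an assay on isolated protein for displacement of a labelled ligand from 5-hydroxytryptamine receptor 6 (Homo sapiens), read by scintillation counting, with a stated time of 1 h; a lower number here means a stronger inhibitor, a higher number a weaker inhibitor. Compound 1 and compound 2 share a core and differ in one group: piperidin-1-yl in place of 4-acetylpiperazin-1-yl on an aromatic carbon. That change gave a 5.6-fold lower number from compound 1 to compound 2 (0.75 log units; beyond the scatter). Compound 3 has the same atoms as compound 1, joined differently; the difference between the two cores is not broken down here. In this assay compound 3 gives 4850 nM, the highest of the three numbers, standing beyond the scatter from both compound 1 and compound 2.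

Compound 4 `O=S(=O)(c1ccccc1)n1ccc2cc(N3CCCCC3)ccc21` has not yet been measured. It is made from compound 3 by the same kind of change as that from compound 1 to compound 2: piperidin-1-yl in place of 4-acetylpiperazin-1-yl on an aromatic carbon. The surroundings of the place are not identical, though: in compound 1 the group sits ortho to a fused ring and meta to a fused ring, while in compound 3 it sits meta to a fused ring and para to a fused ring.

Because the same replacement gave a 5.6-fold lower number from compound 1 to compound 2 (0.75 log units; beyond the scatter), the step from compound 3 to compound 4 is expected to be of a similar size, a 5.4-fold lower number from compound 3 to compound 4 (0.73 log units; beyond the scatter), with wider uncertainty since the change occurs only once among the measured compounds and at a different position. Compound 4 is therefore estimated at 900 nM, within a range from 300 nM to 3000 nM.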

Compound 4, inhibition constant: 360 nM
Beside the measured number, compound 4's estimate is 2.5-fold (0.40 log units) above it, and the stated range covers the measured number.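

In this assay, piperidin-1-yl in place of 4-acetylpiperazin-1-yl also lowers the number on the second core, giving a 13-fold lower number from compound 3 to compound 4 (1.13 log units; beyond the scatter). Set side by side, the two steps point the same way and cannot be told apart in size: the same change on two cores in this assay, a 5.6-fold lower number (0.75 log units; beyond the scatter) from compound 1 to compound 2 and a 13-fold lower number (1.13 log units; beyond the scatter) from compound 3 to compound 4, 2.4-fold (0.38 log units) apart, within the scatter of two such steps. Within the data shown here, this shows the change carrying over between these two cores, but it rests on only two pairs of compounds, so the larger look of the new step should not be read as a real difference, and nothing here shows why the number falls or whether the change would carry to any further core.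

Each step removes the acetyl group and the second ring nitrogen together, so the compounds shown leave open which of the two matters, a question that piperazin-1-yl without its acetyl could help to separate. As far as these compounds go, it also remains open whether other amines, such as morpholin-4-yl or an open-chain dimethylamino group, would follow piperidin-1-yl on either core.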